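Swapping a Methylphenyl for a Pyrimidine on a Quinolone

This account rests on a few compounds, and the source may have more. Where it says the series, first, only, none or still open, it means among the compounds named here.

Of the compounds shown here, two have been measured in an ADME assay on RAW264.7 cells (Mus musculus) for cytotoxicity, read by MTT assay, with a stated time of 72 h; on this read-out higher numbers stand for weaker inhibition and lower numbers for stronger inhibition. Compound 1 `O=C(O)c1cn(C2CC2)c2cc(N3CCN(C(=O)CN4CCN(C(c5ccccc5)c5ccccc5)CC4)CC3)c(F)cc2c1=O` gives 96600 nM. Compound 2 `Cc1cccc(N2CCN(CC(=O)N3CCN(c4cc5c(cc4F)c(=O)c(C(=O)O)cn5C4CC4)CC3)CC2)c1` gives 154000 nM; the two numbers lie within the scatter of one another, so compound 2 stands level with compound 1. Compound 3 `O=C(O)c1cn(C2CC2)c2cc(N3CCN(C(=O)CN4CCN(c5ncccn5)CC4)CC3)c(F)cc2c1=O` has not yet been measured in this assay. It differs from compound 2 in one place: pyrimidin-2-yl in place of 3-methylphenyl on an amine nitrogen in a ring. For the measured compounds named here, no single-change step between measured compounds is available, so the expected step is a 1.3-fold lower number from compound 2 to compound 3 (0.11 log units; within the scatter), nothing beyond the scatter. Compound 3 is therefore estimated at 120000 nM, within a range from 50000 nM to 300000 nM.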

Compound 3, half-maximal inhibitory concentration: 227000 nM
The estimate for compound 3 lay 1.9-fold (0.28 log units) below the measured number, within the range that was stated.
By their numbers in this assay, from the lowest: compounds 1, 2 and 3 (each within the scatter of the next, the first and the last beyond it).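

In this assay, putting pyrimidin-2-yl in place of 3-methylphenyl on this amine nitrogen in a ring gives a 1.5-fold higher number from compound 2 to compound 3 (0.17 log units; within the scatter). At this position, then, a ring of carbon only and a ring with 2 hetero atoms and 2 hydrogen-bond acceptors read alike. No measurement shown bears on why they do. As far as these compounds go, whether the same holds for groups without an aromatic ring on this nitrogen, such as a simple methyl or an acetyl group, stays open. So does the effect of an amine or a carboxylic acid on the aromatic ring.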